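Swapping the urea aryl group: dichlorophenyl to trifluoromethylphenyl

The source may report more compounds than this note shows. Statements on the series, on what has been measured and on what is new or still open speak of the compounds shown alone.

Measured so far:
Compound 1 `COc1cc(Cl)cc(-c2nn(-c3cccc(NC(=O)Nc4ccc(Cl)c(C(F)(F)F)c4)c3)cc2-c2ccncc2)c1` — 35%
Compound 2 `COc1cc(Cl)cc(-c2nn(-c3cccc(NC(=O)Nc4ccc(Cl)c(Cl)c4)c3)cc2-c2ccncc2)c1` — 67%

Both compounds were tested in a functional assay on K562 cells (Homo sapiens) for inhibition, read by sulforhodamine B assay, with a stated time of 48 h, tested at 1 uM; on this read-out higher numbers stand for a weaker effect at the one concentration tested and lower numbers for a stronger effect. Compound 2 gives the higher of the two numbers, that is, the weaker effect. Going by the values given here, the only measured step, a number 32 percentage points higher from compound 1 to compound 2 (beyond the scatter), was large and beyond the scatter.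

Compound 3 `COc1cc(Cl)cc(-c2nn(-c3cccc(NC(=O)Nc4cccc(C(F)(F)F)c4)c3)cc2-c2ccncc2)c1` has not yet been measured. It differs from compound 2 by 3-(trifluoromethyl)phenyl in place of 3,4-dichlorophenyl on an amide-type nitrogen. Among the compounds with values here, this change bears a partial relation to the one measured step: it brings back a trifluoromethyl group, as in compound 1, but at the same time removes the second chloro substituent, so neither measured compound is a direct match. A move back toward the stronger effect of compound 1 is therefore expected, but a smaller one than a number 32 percentage points higher from compound 1 to compound 2 (beyond the scatter). The expected step is a number 17 percentage points lower from compound 2 to compound 3 (beyond the scatter). Compound 3 is estimated at 50%, with a range from 30% to 75%.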

Compound 3, a percentage reported as activity, at one concentration (the size of the read-out at that concentration, not a potency): 45%
Estimate against measurement, compound 3: 5 percentage points above, within the range that was stated.
By their numbers in this assay, from the lowest: compounds 1 and 3 (each within the scatter of the next); then compound 2.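

In this assay, replacing 3,4-dichlorophenyl with 3-(trifluoromethyl)phenyl on the amide-type nitrogen gives a number 22 percentage points lower from compound 2 to compound 3 (beyond the scatter) and shows that the lower number does not depend on keeping a chloro on this ring. Putting hydrogen in place of the chloro of compound 1 gives a number 10 percentage points higher from compound 1 to compound 3 (within the scatter) and so leaves no measurable role for that chloro once trifluoromethyl is present. No measured evidence here explains why these aryl groups differ.

The compounds shown leave open how this ring would behave with a nitrile or an amine in place of the trifluoromethyl group. Going by these compounds alone, they also cannot separate the contributions of the two chloro groups in compound 2, since no compound here carries only one of them on this ring.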